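The compounds below may be only part of what the source reports. "The series", "measured", "known", "first", "only" and "open" are said of these compounds alone.

Three compounds share one core and have been measured:

Compound 1 `COc1ccc2[nH]c3c(c2c1)CCNC31CCN(Cc2ccccc2)CC1` gives 12600 nM in an assay on FRT cells for positive allosteric modulation of Cystic fibrosis transmembrane conductance regulator variant N1303K (Homo sapiens), in the presence of a further agent that is not named here; a higher number here means that more compound is needed for the effect, a lower number that less compound is needed.
Compound 2 `COc1ccc2[nH]c3c(c2c1)CCNC31CCN(Cc2c(F)ccc(Cl)c2F)CC1` gives 1500 nM in this assay.
Compound 3 `COc1ccc2[nH]c3c(c2c1)CCNC31CCN(Cc2ccc(F)c(F)c2F)CC1` gives 4100 nM in this assay.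

Compound 3 stands second highest of the three numbers: it lies a 3.1-fold lower number from compound 1 to compound 3 (0.49 log units; beyond the scatter) and a 2.7-fold higher number from compound 2 to compound 3 (0.44 log units; beyond the scatter). Compound 4 `COc1ccc2[nH]c3c(c2c1)CCNC31CCN(Cc2ccccn2)CC1` has not been measured. It differs from compound 3 in one place: pyridin-2-yl in place of 2,3,4-trifluorophenyl on a saturated chain carbon bound to an amine nitrogen in a ring. All three measured steps concern the same ring on that chain carbon, and each of them beyond the scatter. Adding halogens to the plain phenyl of compound 1 gave an 8.4-fold lower number from compound 1 to compound 2 (0.92 log units; beyond the scatter) and a 3.1-fold lower number from compound 1 to compound 3 (0.49 log units; beyond the scatter), while moving between the two halogenated rings gave a 2.7-fold higher number from compound 2 to compound 3 (0.44 log units; beyond the scatter). Compound 4 carries a pyridin-2-yl with no halogens, so it resembles compound 1 more than compound 3 in that respect, and a step back toward the number of compound 1 is expected, a 2.4-fold higher number from compound 3 to compound 4 (0.39 log units; beyond the scatter). Among the compounds with values here, no measured step tells how the ring nitrogen itself acts, so the range is wide. Compound 4 is estimated at 10000 nM, between 3000 nM and 35000 nM.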

Compound 4, half-maximal effective concentration: 11500 nM
The estimate for compound 4 lay 1.2-fold (0.06 log units) below the measured number; measured number inside the range.
By their numbers in this assay, from the lowest: compound 2; then compound 3; then compounds 4 and 1 (each within the scatter of the next).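

Replacing a halogenated ring with pyridin-2-yl gives up the gain seen in this assay: the number rises, with a 2.8-fold higher number from compound 3 to compound 4 (0.45 log units; beyond the scatter) and a 7.7-fold higher number from compound 2 to compound 4 (0.88 log units; beyond the scatter). Set against the plain phenyl, pyridin-2-yl gives a 1.1-fold lower number from compound 1 to compound 4 (0.04 log units; within the scatter), so at this position a nitrogen in the aromatic ring does not separate compound 4 from compound 1, and among these four compounds only the two rings carrying halogens give lower numbers than compound 1. No measurement is available here that explains these differences.

From the compounds shown here alone, it remains open whether fluorine or chlorine on the pyridin-2-yl ring would lower the number as they do on phenyl. Going by these compounds, it is also open whether pyridin-3-yl or a saturated ring such as cyclohexyl would read like pyridin-2-yl and phenyl.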